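A few compounds are considered here, and "the series" means these few. Any claim that something is new, unique, unknown or untested is made for them only; others in the source may bear on it.

Among the compounds with values here, compound 1 `COc1ccc(Nc2nc(-c3cccc(F)c3)nc3ccc(F)cc23)cc1` is the only member of this small set with a number of its own in a functional assay on U2OS cells (Homo sapiens) for cytotoxicity, read by MTT assay, with a stated time of 48 h; on this read-out higher numbers stand for weaker inhibition and lower numbers for stronger inhibition: compound 1 gives 32300 nM. Compound 2 `Fc1cccc(-c2nc(Nc3cccc(Cl)c3)c3cc(F)ccc3n2)c1` reaches only a limit of the assay, giving > 50000 nM. Compound 3 `Oc1ccc(Nc2nc(-c3cccc(F)c3)nc3ccc(F)cc23)cc1` likewise stops at a limit, with > 50000 nM. Both measured steps from compound 1 therefore run towards weaker inhibition: an at least 1.5-fold higher number from compound 1 to compound 2 (0.18 log units; that floor lies within the scatter), and an at least 1.5-fold higher number from compound 1 to compound 3 (0.18 log units; that floor lies within the scatter), while the step between compound 2 and compound 3 is a step that the two limits leave unreadable from compound 2 to compound 3. Two of the three values shown sit at the limit of > 50000 nM in this assay, at which 2 of the 3 values shown sit.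

Compound 4 `Nc1cccc(Nc2nc(-c3cccc(F)c3)nc3ccc(F)cc23)c1` differs from compound 1 in one place: 3-aminophenyl in place of 4-methoxyphenyl on a nitrogen on an aromatic ring. Both measured steps bear on this change: the step to compound 2 also exchanges the 4-methoxyphenyl for a differently substituted phenyl, and the step to compound 3 also brings in a hydrogen-bond donor. Each of those moved the number up at least to the limit, so compound 4 is expected to move the same way, by a step of a 1.5-fold higher number from compound 1 to compound 4 (0.17 log units; within the scatter). Compound 4 is thus estimated at 48000 nM, within a range from 20000 nM to 120000 nM, with a real chance that this assay again reports only a limit.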

Compound 4, half-maximal inhibitory concentration: 49700 nM
Compound 4: middle estimate off by 1.0-fold (0.02 log units), on the low side; the measured number falls inside the stated range.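

In this assay the new value is a readable number rather than a limit, so a change of the group on this nitrogen now has a size. Exchanging 4-methoxyphenyl for 3-aminophenyl, which brings in a hydrogen-bond donor, gives a 1.5-fold higher number from compound 1 to compound 4 (0.19 log units; within the scatter) and therefore produces no difference that can be told from the scatter. The other two steps are a number no higher from compound 2 to compound 4 (the limit leaves the size open) and a number no higher from compound 3 to compound 4 (the limit leaves the size open) and their size cannot be read, because the compounds they start from stop at a limit of the assay: the limit of > 50000 nM in this assay, at which 2 of the 4 values shown sit.

All the groups shown on this nitrogen are substituted phenyl rings, so it remains open whether a benzyl or a piperidine there would give stronger inhibition. Also open, going by these compounds, is how an acetamide or a carboxylic acid on that phenyl ring would read in this assay.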